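The source may hold more compounds than are shown below. What is called first, only, known or untested is meant among the compounds shown, and "the series" means these compounds.

Compound 1 `Nc1nc(NC2CC2)c2ncn(/C=C3/CC3(CO)CO)c2n1`; compound 2 `CCCCCOc1nc(N)nc2c1ncn2/C=C1/CC1(CO)CO`; compound 3 `CCCCNc1nc(N)nc2c1ncn2/C=C1/CC1(CO)CO`, not yet measured.

In an ADME assay on MOLT-3 cells (Homo sapiens) for cytotoxicity, with a stated time of 7 days (a lower number here means that less compound is tolerated, a higher number that more compound is tolerated), compound 1 gives > 20000 nM, a limit of the assay rather than a number. Compound 2 gives > 20000 nM in this assay, again a limit. Among the compounds with values here, compound 1 thus stands only at a limit, and the one further value shown is a limit too, so a step that the two limits leave unreadable from compound 1 to compound 2 cannot be sized. The change to compound 3 is butyl in place of cyclopropyl on a nitrogen on an aromatic ring. Within the data shown here, the single measured step, pentyloxy in place of cyclopropylamino, is unreadable; with both values at the limit of > 20000 nM in this assay, at which 2 of the 2 values shown sit, nothing fixes the size or direction of this step. Compound 3 is expected at 20000 nM, range 10000 nM to 40000 nM. The expected step is a number no higher from compound 1 to compound 3 (the limit leaves the size open), none beyond the scatter.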

Compound 3, half-maximal cytotoxic concentration: > 20000 nM
Compound 3 ended at the assay's limit; the forecaster's own chance of this, stated with the estimate: 85%; the middle value sits exactly at the limit.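

No step among compound 1, compound 2 and compound 3 can be read in this assay, and all three stand at a limit: the limit of > 20000 nM in this assay, at which 3 of the 3 values shown sit.

On these data alone, the cytotoxic concentration of each compound, and so the size and direction of any step among them, stays open.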